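Swapping a Cyclohexyl Amide for a Nitrophenyl Amide

The compounds below may be only part of what the source reports. "The series", "measured", "known", "first", "only" and "open" are said of these compounds alone.

Compound 1 `O=C(Nc1ccc(Cl)cc1CN1C(=O)c2ccccc2C1=O)C1CCCCC1` belongs to a small set of three compounds built on one shared core and tested in an assay on CHO cells for positive allosteric modulation of metabotropic glutamate receptor 5 (Homo sapiens), read by FLIPR; on this read-out lower numbers stand for an effect already at smaller amounts and higher numbers for an effect only at larger amounts of compound; in that test compound 1 gives 1500 nM. Going by the values given here, compound 3 `Cc1ccc2c(c1C)C(=O)N(Cc1cc(Cl)ccc1NC(=O)c1ccccn1)C2=O` gives 2200 nM, a number that lies within the usual scatter of the one for compound 1, so the two cannot be told apart. Compound 2 `CCOc1cccc2c1C(=O)N(Cc1cc(Cl)ccc1NC(=O)c1ccccn1)C2=O` gives 280 nM, clearly lower than compound 1, leaving compound 1 with the second highest of the three numbers. Compound 4 `O=C(Nc1ccc(Cl)cc1CN1C(=O)c2ccccc2C1=O)c1ccccc1[N+](=O)[O-]` has not yet been measured and differs from compound 1 in one place: 2-nitrophenyl in place of cyclohexyl on a carbonyl carbon. Among the compounds with values here, no measured pair shows this exact change, so the expectation rests on the spread seen so far; in this assay a modest step toward lower numbers is expected a 1.9-fold lower number from compound 1 to compound 4 (0.27 log units; within the scatter). Compound 4 is accordingly estimated at 800 nM, with a likely range from 250 nM to 2500 nM.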

Compound 4, half-maximal effective concentration: 5700 nM
Compound 4: middle estimate off by 7.1-fold (0.85 log units), on the low side, outside the stated range (above it).
By their numbers in this assay, from the lowest: compound 2; then compounds 1 and 3 (each within the scatter of the next); then compound 4.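

In this assay, the step is a 3.8-fold higher number from compound 1 to compound 4 (0.58 log units; beyond the scatter) when 2-nitrophenyl replaces cyclohexyl on the carbonyl carbon, giving the first direct sign that the group at this position matters. This single change brings in both an aromatic ring and a nitro group, so the step cannot separate the two. Nothing measured here explains the rise.

Going by these compounds, whether plain phenyl would fall closer to cyclohexyl or to 2-nitrophenyl remains open. So does the outcome of an amine in place of the nitro group.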